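Chloro on the pyrazole-bound phenyl: a repeated change

This account rests on a few compounds, and the source may have more. Where it says the series, first, only, none or still open, it means among the compounds named here.

Compound 1 `N#Cc1c(-c2nnc(O)c3nn(-c4ccccc4)cc23)nn(-c2ccccc2)c1-c1ccccc1` carries a hydroxy group on its shared core. In a functional assay on T47D cells (Homo sapiens) for inhibition, read by sulforhodamine B assay, with a stated time of 48 h (a higher number here means a weaker inhibitor of growth, a lower number a stronger inhibitor of growth), compound 1 gives 2950 nM. Compound 2 `N#Cc1c(-c2nnc(O)c3nn(-c4ccc(Cl)cc4)cc23)nn(-c2ccccc2)c1-c1ccccc1` differs from compound 1 by chloro in place of hydrogen on an aromatic carbon. In this assay compound 2 gives > 100000 nM, which is a limit of the assay rather than a number. That change made an at least 33-fold higher number from compound 1 to compound 2 (1.53 log units; beyond the scatter), with one value sitting at the limit of > 100000 nM in this assay, at which 1 of the 3 values shown sits.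

Compound 3 `N#Cc1c(-c2nnc(-c3nn(-c4ccccc4)c(-c4ccccc4)c3C#N)c3nn(-c4ccccc4)cc23)nn(-c2ccccc2)c1-c1ccccc1` replaces the hydroxy group of compound 1 with a second copy of the cyanopyrazole unit; the difference between the two cores is not broken down here. In this assay compound 3 gives 81000 nM, already the higher of the two numbers shown.

Compound 4 `N#Cc1c(-c2nnc(-c3nn(-c4ccccc4)c(-c4ccccc4)c3C#N)c3nn(-c4ccc(Cl)cc4)cc23)nn(-c2ccccc2)c1-c1ccccc1`, not yet measured, differs from compound 3 by chloro in place of hydrogen on an aromatic carbon, the same change that led from compound 1 to compound 2. Because an at least 33-fold higher number from compound 1 to compound 2 (1.53 log units; beyond the scatter) was a large weakening, compound 4 is expected to show a step of a 1.9-fold higher number from compound 3 to compound 4 (0.27 log units; within the scatter) in this assay. Starting from the high number of compound 3, the expected value for compound 4 in this assay is 150000 nM, and the reading will very likely be reported only as a limit.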

Compound 4, concentration for 50% growth inhibition: 16000 nM
Compound 4: the middle estimate sits 9.4-fold (0.97 log units) above what was measured; the measured number lies below the stated range.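

In this assay the change from phenyl to 4-chlorophenyl gave a 5.1-fold lower number from compound 3 to compound 4 (0.70 log units; beyond the scatter), which runs in the opposite direction to the step seen on the hydroxy core. The same small change therefore did not carry over from one core to the other, in either size or direction: the same change on two cores in this assay, an at least 33-fold higher number (1.53 log units; beyond the scatter) from compound 1 to compound 2 and a 5.1-fold lower number (0.70 log units; beyond the scatter) from compound 3 to compound 4, at least 170-fold (2.23 log units) apart, beyond the scatter of two such steps What this does not show is why the two cores respond differently or what the change would do on a third core, and the comparison rests in part on compound 2, whose reading is a limit and not a number: the limit of > 100000 nM in this assay, at which 1 of the 4 values shown sits.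

Still open, from the compounds shown here alone, is how a bromo group, a methoxy group or an amine in that same place on the phenyl ring would read on each core. Also open, going by these compounds, is whether a core bearing a carboxylic acid in place of the hydroxy group would respond to chloro as the core of compound 1 does or as the core of compound 3 does.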